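Adding Trifluoromethyl to the Shared Core of Compound 2

A few compounds are considered here, and "the series" means these few. Any claim that something is new, unique, unknown or untested is made for them only; others in the source may bear on it.

In a functional assay on cells for agonist activity at Free fatty acid receptor 1 (Homo sapiens), read by FLIPR and calcium flux (a higher number here means that more compound is needed for the effect, a lower number that less compound is needed), two compounds have been measured:
compound 1, `CC#C[C@@H](Cc1nnn[nH]1)c1ccc(OCc2ccc3scc(-c4cncnc4C)c3c2)cc1`, gives 37 nM
compound 2, `CC#C[C@@H](Cc1nnn[nH]1)c1ccc(OCc2ccc3scc(-c4ccc(OCCOC)cc4C)c3c2)cc1`, gives 9 nM

Compound 2 holds the lowest number of the two, the step of a 4.1-fold lower number from compound 1 to compound 2 (0.61 log units; beyond the scatter) separating it from compound 1. Compound 3, `CC#C[C@@H](Cc1nnn[nH]1)c1ccc(OCc2ccc3sc(C(F)(F)F)c(-c4ccc(OCCOC)cc4C)c3c2)cc1`, differs from compound 2 by trifluoromethyl in place of hydrogen on an aromatic carbon. Among the compounds with values here, no measured step touches this position, so nothing measured bears directly on the change. The step from compound 2 to compound 3 in this assay is therefore expected to stay within the scatter, a 1.3-fold higher number from compound 2 to compound 3 (0.12 log units; within the scatter). Compound 3 is estimated at 12 nM, with a range from 4 nM to 40 nM.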

Compound 3, half-maximal effective concentration: 13 nM
For compound 3 the middle estimate is 1.1-fold (0.03 log units) below the measured one, within the range that was stated.
By their numbers in this assay, from the lowest: compounds 2 and 3 (each within the scatter of the next); then compound 1.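

In this assay, within the data shown here, a 1.4-fold higher number from compound 2 to compound 3 (0.16 log units; within the scatter) is the first measured step at this aromatic carbon next to the ring sulfur. The shared core therefore keeps its number, within the scatter, when trifluoromethyl, with its 4 heavy atoms, takes the place of hydrogen here. Nothing measured explains this result. On these data alone, whether methyl, chlorine or a nitrile on this carbon would also stay within the scatter remains open. So does whether trifluoromethyl would do the same alongside the 4-methylpyrimidin-5-yl group of compound 1.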